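Swapping bromo for amino on a fused core

A few compounds are considered here, and "the series" means these few. Any claim that something is new, unique, unknown or untested is made for them only; others in the source may bear on it.

Among the compounds with values here, compound 2 `CC(C)n1nc(-c2ccc3oc(N)nc3c2)c2c(Br)nc(N)nc21` is the one compound here with a number rather than a limit in a physicochemical assay for solubility, read by HPLC, in phosphate buffer, measured as kinetic solubility, with a stated time of 24 h, at 20 degrees C, at pH 7.4, tested at 100 uM (on this read-out higher numbers stand for higher solubility and lower numbers for lower solubility), and in this assay compound 2 gives 4000 nM. Compound 1 `COc1nc(N)nc2c1c(-c1ccc3oc(N)nc3c1)nn2C(C)C` carries a methoxy where compound 2 carries a bromo. In this assay compound 1 gives < 1000 nM, which is a limit of the assay and not a number. This is the situation described by the limit of < 1000 nM in this assay, at which 1 of the 2 values shown sits. Within the data shown here, the step of an at least 4.0-fold higher number from compound 1 to compound 2 (0.60 log units; beyond the scatter) is the only measured comparison, and it shows that exchanging the group on this aromatic carbon can shift solubility by a clear margin.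

Compound 3 `CC(C)n1nc(-c2ccc3oc(N)nc3c2)c2c(N)nc(N)nc21` differs from compound 2 by amino in place of bromo on an aromatic carbon. Among the measured compounds shown here, no measured step covers an amino at this position, so the single measured step gives only the scale such a swap can produce, not its direction for this case. On that basis the step expected is a 2.0-fold higher number from compound 2 to compound 3 (0.30 log units; within the scatter), a modest rise rather than none. Compound 3 is therefore estimated to reach 8000 nM, with a range from 2000 nM to 30000 nM.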

Compound 3, solubility: 88000 nM
Estimate against measurement, compound 3: 11-fold (1.04 log units) below; the measured number lies above the stated range.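

Amino in place of bromo on this aromatic carbon, next to the ring nitrogen, gives in this assay a 22-fold higher number from compound 2 to compound 3 (1.34 log units; beyond the scatter), so the earlier compounds' hint that this position matters now has a direction and a size for amino, and of the three groups shown amino gives the highest number. Set against methoxy on the same carbon, the change gives an at least 88-fold higher number from compound 1 to compound 3 (1.94 log units; beyond the scatter), and both of these steps come from a swap at this one place while the rest of the structure stays the same. That second step is only a lower bound, as compound 1 stands at a limit of the assay and not at a number: the limit of < 1000 nM in this assay, at which 1 of the 3 values shown sits.

The compounds shown cannot tell whether this rise needs the plain amino group or would also appear with a methylamino, a dimethylamino or a hydroxyl group on the same carbon. They also leave open whether amino in place of bromo would give a step of this size if another part of the molecule were changed, such as the group on the second ring nitrogen.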